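A few compounds are considered here, and "the series" means these few. Any claim that something is new, unique, unknown or untested is made for them only; others in the source may bear on it.

Measured compounds:
compound 1 `C=CC(=O)Nc1cccc(NC(=O)CSc2nc(Nc3ccccc3Cl)c3ccccc3n2)c1`; in a functional assay on PC-3 cells (Homo sapiens) for inhibition, read by MTT assay, with a stated time of 72 h (a higher number here means a weaker inhibitor, a lower number a stronger inhibitor), compound 1 gives 14400 nM
compound 2 `C=CC(=O)Nc1cccc(NC(=O)CSc2nc(Nc3cccc(F)c3)c3ccccc3n2)c1`; compound 2 gives 5370 nM
compound 3 `C=CC(=O)Nc1cccc(NC(=O)CSc2nc(Nc3ccc(F)cc3)c3ccccc3n2)c1`; compound 3 gives 8240 nM

Compound 3 stands second highest of the three numbers. Its nearest neighbour is compound 2, and the step of a 1.5-fold higher number from compound 2 to compound 3 (0.19 log units; within the scatter) lies within the scatter; the step of a 1.7-fold lower number from compound 1 to compound 3 (0.24 log units; within the scatter) lies within the scatter as well, so compound 3 cannot be set apart from either of the other two on these numbers.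

Compound 4 `C=CC(=O)Nc1cccc(NC(=O)CSc2nc(Nc3ccc(Cl)c(Cl)c3)c3ccccc3n2)c1` has not yet been measured in this assay. It differs from compound 3 in one place: 3,4-dichlorophenyl in place of 4-fluorophenyl on a nitrogen on an aromatic ring. Among the measured compounds shown here, no measured step exchanges a single halogen on this phenyl group for two, so the change has no direct precedent. For the measured compounds named here, the steps that bear on it are the three exchanges of one halophenyl group for another on the same nitrogen: a 2.7-fold lower number from compound 1 to compound 2 (0.43 log units; beyond the scatter), a 1.7-fold lower number from compound 1 to compound 3 (0.24 log units; within the scatter) and a 1.5-fold higher number from compound 2 to compound 3 (0.19 log units; within the scatter). Only the first of these goes beyond the scatter, and all three keep the numbers within a narrow band. The expectation is therefore a step of a 1.4-fold lower number from compound 3 to compound 4 (0.14 log units; within the scatter), not beyond the scatter. Compound 4 is estimated at 6000 nM, with a range from 2000 nM to 18000 nM.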

Compound 4, half-maximal inhibitory concentration: 27600 nM
Compound 4: middle estimate off by 4.6-fold (0.66 log units), on the low side, and the stated range ends below it.
By their numbers in this assay, from the lowest: compounds 2, 3, 1 and 4 (each within the scatter of the next, the first and the last beyond it).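

In this assay, the 3,4-dichlorophenyl group on this nitrogen shows that exchanges at this position are not confined to the narrow band of the earlier halophenyl compounds, since it separates compound 4 from both fluorophenyl compounds (a 3.3-fold higher number from compound 3 to compound 4 (0.52 log units; beyond the scatter); a 5.1-fold higher number from compound 2 to compound 4 (0.71 log units; beyond the scatter)). The two chlorine-bearing compounds cannot be told apart (a 1.9-fold higher number from compound 1 to compound 4 (0.28 log units; within the scatter)), but this is no clean split between chlorine and fluorine, because compound 3, which goes against such a pattern, also lies within the scatter of compound 1 (a 1.7-fold lower number from compound 1 to compound 3 (0.24 log units; within the scatter)). The data shown offer no measurement that would account for this change at the position.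

Because the step from compound 3 to compound 4 changes both the kind of halogen and the number of halogens at once, the compounds shown do not separate the contribution of each, and a phenyl group carrying a single chlorine in the place of the 4-fluorophenyl fluorine would be needed to do so. They also leave open whether this nitrogen tolerates a phenyl group carrying no halogen at all, such as one bearing a methoxy group or an amine.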